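Losing One Methoxy Group: From Compound 3 to Compound 4

This account rests on a few compounds, and the source may have more. Where it says the series, first, only, none or still open, it means among the compounds named here.

Three compounds built on one shared core were tested in a functional assay on the whole organism (strain albino) for inhibition, with Rattus norvegicus as the target, read by paw edema, with stated times of 30 min and 3 h, at a dose of 100 mg/kg by the oral route; on this read-out higher numbers stand for more inhibition at the one dose given (going by the name of the read-out) and lower numbers for less inhibition. Compound 1 `COc1ccc(C2=NNC(c3ccco3)C2)cc1OC` gives 60%, compound 2 `COc1ccc(C2CC(c3ccc(OC)c(OC)c3)=NN2)c(OC)c1` gives 42%, and compound 3 `COc1ccc(C2=NNC(c3c(Cl)cccc3Cl)C2)cc1OC` gives 58%. Compound 3 therefore sits in the upper pair of the three: its reading lies within the usual scatter of compound 1, while its gap to compound 2 lies beyond the scatter. Compound 4 `COc1ccc(C2=NNC(c3c(Cl)cccc3Cl)C2)cc1` differs from compound 3 by a single change: hydrogen in place of methoxy on an aromatic carbon. Within the data shown here, no measured pair shows this change, so its effect on paw edema is unknown. Compound 4 is expected to give 50% in this assay, with a range from 32% to 68%. The step of a number 8 percentage points lower from compound 3 to compound 4 (within the scatter) is estimated to be small, most likely within the scatter in either direction.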

Compound 4, a percentage reported as inhibition, in the whole organism at one dose (the size of the read-out at that dose, not a potency): 60%
The estimate for compound 4 lay 10 percentage points below the measured number; low and high end bracket the measured number.
By their numbers in this assay, from the lowest: compound 2; then compounds 3, 1 and 4 (each within the scatter of the next).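

In this assay, among these compounds, a number 2 percentage points higher from compound 3 to compound 4 (within the scatter) gives the first direct reading of this change and shows that hydrogen in place of methoxy at this position, ortho to a methoxy group, leaves the inhibition at this one dose within the scatter. The methoxy group here is therefore not required for the effect in this pair. Nothing available explains this result. From the compounds shown here alone, it remains open how an amine or a carboxylic acid at this position would read, and whether the remaining methoxy group can also be replaced by hydrogen.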